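Aryl glyoxamide series: ester extension at the alanine carbon

A few compounds are considered here, and "the series" means these few. Any claim that something is new, unique, unknown or untested is made for them only; others in the source may bear on it.

Of the compounds shown here, two of the shared core have been measured. Compound 1, `CCOC(=O)c1ccc(NC(=O)C(=O)c2ccccc2NC(C)=O)cc1`, gives 990000 nM in an assay on mitochondria from brain for inhibition of Amine oxidase [flavin-containing] B (Bos taurus); on this read-out higher numbers stand for weaker inhibition and lower numbers for stronger inhibition. Compound 2, `COC(=O)[C@H](C)NC(=O)c1ccc(NC(=O)C(=O)c2ccccc2NC(C)=O)cc1`, gives 730000 nM in this assay; the step of a 1.4-fold lower number from compound 1 to compound 2 (0.13 log units; within the scatter) is within the scatter, so compounds 1 and 2 stand together and neither is separated from the other on these numbers. Both sit at very weak inhibition.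

Compound 3, `COC(=O)C[C@H](NC(=O)c1ccc(NC(=O)C(=O)c2ccccc2NC(C)=O)cc1)C(=O)OC`, is not yet measured. It differs from compound 2 by methoxycarbonyl in place of hydrogen on a saturated chain carbon, two bonds along the chain from an amide-type nitrogen and a carbonyl carbon, that is, the 1-(methoxycarbonyl)ethyl group becomes a 1,2-bis(methoxycarbonyl)ethyl group on the amide nitrogen of the benzamide.

For the measured compounds named here, the only measured step, from compound 1 to compound 2, also varied this part of the molecule (ethoxy to (1-(methoxycarbonyl)ethyl)amino) and stayed within the scatter. Going by the values given here, nothing measured so far shows that this end of the molecule moves the number in this assay. The expectation for compound 3 is therefore a step of a 1.0-fold lower number from compound 2 to compound 3 (0.02 log units; within the scatter) that stays within the scatter, with no direction favoured. Compound 3 is estimated at 700000 nM in this assay, expected to fall between 300000 nM and 1600000 nM.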

Compound 3, half-maximal inhibitory concentration: 790000 nM
Beside the measured number, compound 3's estimate is 1.1-fold (0.05 log units) below it, and the stated range covers the measured number.
By their numbers in this assay, from the lowest: compounds 2, 3 and 1 (each within the scatter of the next).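

Placing methoxycarbonyl on the saturated chain carbon, which turns 1-(methoxycarbonyl)ethyl into 1,2-bis(methoxycarbonyl)ethyl, gives a 1.1-fold higher number from compound 2 to compound 3 (0.03 log units; within the scatter) in this assay and so leaves the read-out where it stood. For the compounds shown here, this is the first measured change confined to the chain carbon itself, and it shows that an added group of 4 heavy atoms with 2 hydrogen-bond acceptors does not separate compound 3 from compound 2. The larger replacement of ethoxy by (1,2-bis(methoxycarbonyl)ethyl)amino, a 1.3-fold lower number from compound 1 to compound 3 (0.10 log units; within the scatter) on the same read-out, also stays within the scatter, so compounds 1, 2 and 3 stand together at very weak inhibition and nothing available explains why this end of the molecule shows no separation.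

Going by these compounds, it remains open whether a free carboxylic acid in place of a methyl ester, a primary amine or a longer chain on this carbon would produce a step beyond the scatter in this assay on this series. Also open, on these data alone, is whether a change elsewhere on the shared core, such as a free amine in place of the acetylamino group, would move the number at all.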